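The source may report more compounds than this note shows. Statements on the series, on what has been measured and on what is new or still open speak of the compounds shown alone.

In a functional assay on HT cells (Homo sapiens) for antiproliferative activity, read by fluorescence, with a stated time of 72 h (on this read-out lower numbers stand for stronger inhibition of growth and higher numbers for weaker inhibition of growth), compound 1 `CC(O)CSc1nc(NCc2ccc(-c3ccccn3)cc2)c2[nH]nc(C(C)C)c2n1` gives 62 nM, while compound 2 `COCSc1nc(NCc2ccc(-c3ccccn3)cc2)c2[nH]nc(C(C)C)c2n1` gives 340 nM, the higher of the two numbers, so compound 2 is the weaker growth inhibitor so far. Compound 3 `CC(=O)NCCSc1nc(NCc2ccc(-c3ccccn3)cc2)c2[nH]nc(C(C)C)c2n1` keeps the shared core and alters only the chain on sulfur: acetamidomethyl in place of methoxy on a saturated chain carbon bound to a sulfur. Read one bond further out, this is methoxymethyl giving way to 2-acetamidoethyl. Going by the values given here, one measured step bears on this change: a 5.5-fold higher number from compound 1 to compound 2 (0.74 log units; beyond the scatter), where methoxy replaced 1-hydroxyethyl at the same place. It shows that the number responds to changes here and that methoxy gave the higher value of the two groups tried. A single step is thin support, but a modest move toward a lower number seems more likely than a further rise. The expected step is a 2.0-fold lower number from compound 2 to compound 3 (0.30 log units; within the scatter). Compound 3 is estimated at 170 nM, with an expected range of 50 nM to 550 nM.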

Compound 3, concentration for 50% growth inhibition: 71 nM
Estimate against measurement, compound 3: 2.4-fold (0.38 log units) above; measured number inside the range.
By their numbers in this assay, from the lowest: compounds 1 and 3 (each within the scatter of the next); then compound 2.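

In this assay, the step of a 4.8-fold lower number from compound 2 to compound 3 (0.68 log units; beyond the scatter) shows that the number at this place on the chain attached to sulfur can fall as well as rise, and that the higher value of compound 2 is not shared by every replacement of 1-hydroxyethyl. The step of a 1.1-fold higher number from compound 1 to compound 3 (0.06 log units; within the scatter) lies within the scatter, so two differently built groups, 1-hydroxyethyl and acetamidomethyl, cannot be told apart here. In going from methoxy to acetamidomethyl, the chain gains heavy atoms, a double bond and a hydrogen-bond donor, and these compounds cannot show which of these changes matters.

No measurement shown here explains the change in growth inhibition. Going by these compounds, it also remains open whether an amine, a carboxylic acid or a longer chain at this place would keep the number as low.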